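The compounds below may be only part of what the source reports. "The series", "measured", "known", "first", "only" and "open" are said of these compounds alone.

Measured so far in a functional assay on SK-OV-3 cells (Homo sapiens) for cytotoxicity, read by MTT assay, with a stated time of 48 h; on this read-out lower numbers stand for stronger inhibition and higher numbers for weaker inhibition: compound 1 `Cn1cccc1C(=O)/C=C/c1ccc2c(c1)B(O)OC2` at 93600 nM; compound 2 `O=C(/C=C/c1ccc2c(c1)B(O)OC2)c1ccc(Cl)cc1` at 3700 nM.

Among the compounds with values here, compound 2 holds the lower of the two numbers, with compound 1 as its only neighbour; the one measured step, a 25-fold lower number from compound 1 to compound 2 (1.40 log units; beyond the scatter), exchanges the whole aryl group on the carbonyl and says nothing about a change within that ring. Compound 3 `O=C(/C=C/c1ccc2c(c1)B(O)OC2)c1ccc(Br)cc1` carries bromo in place of chloro on an aromatic carbon. Within the data shown here, no measured step tests such a swap, so the expectation rests on compound 2 alone. For compound 3 the expected step is a 1.2-fold lower number from compound 2 to compound 3 (0.09 log units; within the scatter), within the scatter. Compound 3 is estimated at 3000 nM, range 1200 nM to 8000 nM.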

Compound 3, half-maximal inhibitory concentration: 4500 nM
Beside the measured number, compound 3's estimate is 1.5-fold (0.18 log units) below it; measured number inside the range.
By their numbers in this assay, from the lowest: compounds 2 and 3 (each within the scatter of the next); then compound 1.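

Bromo in place of chloro on an aromatic carbon, para to a large group, gives a 1.2-fold higher number from compound 2 to compound 3 (0.09 log units; within the scatter) in this assay, so at this position the two halogens cannot be told apart. 4-Bromophenyl in place of 1-methyl-1H-pyrrol-2-yl gives a 21-fold lower number from compound 1 to compound 3 (1.32 log units; beyond the scatter), which shows that the large step on the carbonyl carbon is not confined to the 4-chlorophenyl group. No supporting evidence bears on either step.

Still open, as far as these compounds go, is how an amine, a carboxylic acid or a methoxy group at this position would read. The unsubstituted phenyl group also remains to be placed against both halogens.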